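This account rests on a few compounds, and the source may have more. Where it says the series, first, only, none or still open, it means among the compounds named here.

Measured so far in an assay on Sf9 cells for inhibition of prolyl hydroxylase EGLN2 (Homo sapiens), read by TR-FRET, with stated times of 30 min and 2 h; a higher number here means a weaker inhibitor, a lower number a stronger inhibitor:
- compound 1, `O=C(O)CNC(=O)c1c(O)c2c(n(Cc3ccc(C(F)(F)F)cc3)c1=O)COCC2`: 11 nM
- compound 2, `O=C(O)CNC(=O)c1c(O)c2c(n(Cc3ccc(Cl)cc3)c1=O)COC2`: 2.1 nM
- compound 3, `O=C(O)CNC(=O)c1c(O)c2c(n(Cc3ccc(F)cc3F)c1=O)COC2`: 2.2 nM

Compound 3 stands second highest of the three numbers in this assay. Its nearest neighbour is compound 2, which differs from it only in the aryl group on the saturated chain carbon bound to the aromatic nitrogen; the step of a 1.0-fold higher number from compound 2 to compound 3 (0.02 log units; within the scatter) is within the scatter. Going by the values given here, compound 1 differs from compound 3 in two places, the core and the aryl group, and no single step can be drawn; its number is the highest of the three, beyond the scatter from compound 3.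

Compound 4, `O=C(O)CNC(=O)c1c(O)c2c(n(Cc3cc(F)c(F)cc3F)c1=O)COC2`, is not yet measured. The change from compound 3 is fluoro in place of hydrogen on an aromatic carbon. Among the compounds with values here, the only measured step that bears on it is the aryl exchange from compound 2 to compound 3, which changed the number within the scatter. On that basis the added fluoro is expected to move this assay little, in no clear direction, and the step of a 1.1-fold higher number from compound 3 to compound 4 (0.06 log units; within the scatter) is estimated to stay within the scatter. Compound 4 is therefore expected near 2.5 nM, within 1 nM to 6 nM.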

Compound 4, half-maximal inhibitory concentration: 3.1 nM
For compound 4 the middle estimate is 1.2-fold (0.09 log units) below the measured one; low and high end bracket the measured number.
By their numbers in this assay, from the lowest: compounds 2, 3 and 4 (each within the scatter of the next); then compound 1.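

In this assay, a fluoro placed on the aromatic carbon ortho to a fluoro group, meta to a large group and para to a fluoro group gives a 1.4-fold higher number from compound 3 to compound 4 (0.15 log units; within the scatter), so this position, which carries hydrogen in compound 3, accepts a third fluoro with a step that stays within the scatter. The wider exchange of 4-chlorophenyl for 2,4,5-trifluorophenyl on the same saturated chain carbon reads the same way, with a 1.5-fold higher number from compound 2 to compound 4 (0.17 log units; within the scatter), so the aryl groups of compound 2, compound 3 and compound 4 cannot be told apart by their numbers on this shared core. Nothing on hand offers an explanation for the size of these steps.

From the compounds shown here alone, only hydrogen and fluoro are compared at this position, so it remains open whether a larger or differently built group, such as a methoxy group, an amine or a carboxylic acid, would also leave the number within the scatter. Going by these compounds, it also remains open whether the same fluoro change would behave alike on the core of compound 1.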